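The compounds below may be only part of what the source reports. "The series", "measured", "known", "first", "only" and "open" are said of these compounds alone.

The compounds measured so far in a functional assay on SW480 cells (Homo sapiens) for inhibition, read by luminescence and resazurin assay, with a stated time of 3 days; on this read-out higher numbers stand for weaker inhibition and lower numbers for stronger inhibition:

Compound 1 `CN(C)CCCNc1nc(NCc2ccc(NC(=O)c3ccc(F)cc3)cc2)c2ccccc2n1` gives 14000 nM.
Compound 2 `CN(C)CCCNc1nc(NCc2ccc(NC(=O)c3ccc(CN4CCN(C)CC4)cc3)cc2)c2ccccc2n1` reaches only the limit of the assay, > 20000 nM, and so has no number.
Compound 3 `Cc1ccc2nc(N(C)C)nc(NCc3ccc(C(=O)N4CCC(C(=O)NCc5ccc(F)cc5)CC4)cc3)c2c1` gives 5600 nM.

Among these, compound 1 holds the higher of the two numbers; its nearest neighbour is compound 3, whose number is lower by a margin beyond the scatter. Going by the values given here, the one step that runs between measured compounds differing in a single place, an at least 1.4-fold higher number from compound 1 to compound 2 (0.15 log units; that floor lies within the scatter), ends at a limit (the limit of > 20000 nM in this assay, at which 1 of the 3 values shown sits), so its true size is known only as a floor.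

Compound 4 `CCNc1nc(NCc2ccc(NC(=O)c3ccc(F)cc3)cc2)c2ccccc2n1` differs from compound 1 in one place: hydrogen in place of (dimethylamino)methyl on a saturated chain carbon, two bonds along the chain from a nitrogen on an aromatic ring. Among the compounds with values here, no measured step touches this part of compound 1. The step from compound 1 to compound 2 alters a different group, and compound 3 differs from compound 1 in several places at once. The expectation for compound 4 therefore rests on compound 1 alone and carries wide bounds. Compound 4 is expected to give 18000 nM in this assay, with a range from 6000 nM to 55000 nM. This expected outcome amounts to a 1.3-fold higher number from compound 1 to compound 4 (0.11 log units; within the scatter), no change beyond the scatter, with a real chance that the assay returns only a limit.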

Compound 4, half-maximal inhibitory concentration: 2300 nM
Beside the measured number, compound 4's estimate is 7.8-fold (0.89 log units) above it; measured number outside the range, below it.
By their numbers in this assay, from the lowest: compound 4; then compound 3; then compound 1. At a limit, above all of these: compound 2.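

Cutting the side chain of compound 1 back from (3-(dimethylamino)propyl)amino to ethylamino leaves inhibition stronger rather than weaker, with a 6.1-fold lower number from compound 1 to compound 4 (0.78 log units; beyond the scatter) in this assay. Going by these compounds alone, this is the first measured change at this position, and it shows that, on the shared core with the 4-fluorobenzamide side kept as it is, the (dimethylamino)methyl end of the chain is not needed for inhibition on these cells. Nothing measured here gives a reason for this change.

The compounds shown do not separate the loss of the amine from the shortening of the chain: a plain propylamino group, or a chain of the same length as in compound 1 ending in a hydroxyl group, would tell the two apart. Also open, from the compounds shown here alone, is whether ethylamino would bring a similar change alongside the (4-methylpiperazin-1-yl)methyl group of compound 2, whose own reading is only a limit.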